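The source may hold more compounds than are shown below. What is called first, only, known or untested is meant among the compounds shown, and "the series" means these compounds.

Measured compounds:
- compound 1, `CCCc1nn(C)c2c(NCc3ccc(F)cc3)nc(/C=C/c3cccnc3)nc12`: 940000 nM
- compound 2, `CN1CCN(c2nc(/C=C/c3ccccc3)nc3ccsc23)CC1`: 198000 nM
- compound 3, `COc1cc(/C=C/c2nc(NC3CC3)c3sccc3n2)cc(OC)c1OC`: > 1000000 nM

In a functional assay on L02 cells (Homo sapiens) for inhibition, read by Griess assay, with stated times of 1 h and 24 h (on this read-out higher numbers stand for weaker inhibition and lower numbers for stronger inhibition), compound 3 gives only a limit and no number, namely > 1000000 nM. Compound 3 therefore stands at the limit of > 1000000 nM in this assay, at which 1 of the 3 values shown sits, and nothing tighter is known about it. The two compounds that do carry numbers are both weak on this scale: compound 1 gives 940000 nM in this assay, and compound 2 gives 198000 nM. Going by the values given here, no pair among the measured compounds differs in only one place, so no measured step is available.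

The unmeasured compound 4, `COc1cc(/C=C/c2nc(NCc3ccccc3)c3sccc3n2)cc(OC)c1OC`, differs from compound 3 by benzyl in place of cyclopropyl on a nitrogen on an aromatic ring. With compound 3 known only as a limit, the step can be taken only from that limit, and the account expects an at least 1.2-fold lower number from compound 3 to compound 4 (0.09 log units; that floor lies within the scatter) to amount to little beyond the usual scatter of this assay, in the direction of somewhat stronger inhibition at most. Compound 4 is accordingly estimated at 800000 nM in this assay, with a likely range from 250000 nM to 2000000 nM.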

Compound 4, half-maximal inhibitory concentration: > 1000000 nM
Compound 4 gave a limit, no number (the forecaster's own chance of this, stated with the estimate: 50%); middle value at least 1.2-fold (0.09 log units) from the limit.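

Compound 3 and compound 4 both stop at the same limit rather than at a number, so no step can be read between them: the limit of > 1000000 nM in this assay, at which 2 of the 4 values shown sit.

The compounds shown leave open whether benzyl in place of cyclopropyl on a nitrogen on an aromatic ring alters inhibition in this assay at all.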